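Swapping Fluoro for Methoxy in a Cytotoxicity Series

The source may report more compounds than this note shows. Statements on the series, on what has been measured and on what is new or still open speak of the compounds shown alone.

Measured so far in a functional assay on PC-3 cells (Homo sapiens) for cytotoxicity, read by WST assay, with a stated time of 48 h; a higher number here means a weaker inhibitor, a lower number a stronger inhibitor:
Compound 1 `COc1ccc2c(/C=C(\C#N)C(=O)c3c[nH]c4cc(F)ccc34)c[nH]c2c1` gives 21400 nM.
Compound 2 `COc1ccc2c(/C=C(\C#N)C(=O)c3c[nH]c4cc(OC)ccc34)c[nH]c2c1` gives 27000 nM.
Compound 3 `N#C/C(=C\c1cn(Cc2ccc(Cl)cc2)c2ccccc12)C(=O)c1c[nH]c2cc(F)ccc12` gives only the limit > 50000 nM in this assay, which is a limit of the assay and not a number.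

Compound 1 and compound 2 differ by one change, (methoxy in place of fluoro on an aromatic carbon), and the step is a 1.3-fold higher number from compound 1 to compound 2 (0.10 log units; within the scatter). Compound 4 `COc1ccc2c(C(=O)/C(C#N)=C/c3cn(Cc4ccc(Cl)cc4)c4ccccc34)c[nH]c2c1` carries the same change made on compound 3, (methoxy in place of fluoro on an aromatic carbon), at the same place. The difference between the two cores is not broken down here.

Compound 3 sits at the limit described by the limit of > 50000 nM in this assay, at which 1 of the 3 values shown sits. Since the earlier step was within the scatter, compound 4 is expected to stay near that limit as well, an expected step that the limit leaves unreadable from compound 3 to compound 4. The estimated value for compound 4 in this assay is 60000 nM, expected between 30000 nM and 150000 nM.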

Compound 4, half-maximal inhibitory concentration: > 50000 nM
Compound 4 ended at the assay's limit (the forecaster's own chance of this, stated with the estimate: 70%); the middle value does not contradict the limit.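

Compound 3 and compound 4 both end at a limit of the assay rather than at a number, so no step can be read between them: the limit of > 50000 nM in this assay, at which 2 of the 4 values shown sit.

The compounds shown leave open whether methoxy in place of fluoro changes the result at all on the core of compound 3.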